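A few compounds are considered here, and "the series" means these few. Any claim that something is new, unique, unknown or untested is made for them only; others in the source may bear on it.

Working notes on the series.

Compound 1 `COc1cc(/C=C2\Cc3ccccc3/C(=C\c3ccc([N+](=O)[O-])cc3)C2=O)cc(OC)c1OC` and compound 3 `COc1ccc(/C=C2\Cc3ccccc3/C(=C\c3ccc([N+](=O)[O-])cc3)C2=O)cc1OC` are built on the same core; compound 2 `COc1ccc(/C=C2\CCC/C(=C\c3ccc([N+](=O)[O-])cc3)C2=O)cc1OC` carries a different core, and the difference between the two cores is not broken down here. In a functional assay on HL-60 cells (Homo sapiens) for cytotoxicity (a lower number here means that less compound is tolerated, a higher number that more compound is tolerated), compound 1 gives 550 nM, and in this assay compound 3 gives 560 nM. The change from compound 3 to compound 1 is methoxy in place of hydrogen on an aromatic carbon. It made a 1.0-fold lower number from compound 3 to compound 1 (0.01 log units; within the scatter), so the two values of compound 3 and compound 1 cannot be told apart. In this assay compound 2 gives 4300 nM, a number that stands well above the values of compound 3 and compound 1, beyond the scatter.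

Compound 4 `COc1cc(/C=C2\CCC/C(=C\c3ccc([N+](=O)[O-])cc3)C2=O)cc(OC)c1OC` is not yet measured. The change from compound 2 to compound 4 is methoxy in place of hydrogen on an aromatic carbon, the same change in the same surroundings as from compound 3 to compound 1. For the measured compounds named here, the only precedent for it sits on the other core, where the step from compound 3 to compound 1 was within the scatter, so for compound 4 a step of about no change at the digits printed from compound 2 to compound 4 (within the scatter) is expected. Compound 4 is therefore estimated at 4300 nM, with a range from 2000 nM to 9500 nM.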

Compound 4, half-maximal cytotoxic concentration: 1100 nM
Beside the measured number, compound 4's estimate is 3.9-fold (0.59 log units) above it, and the stated range ends above it.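

In this assay, methoxy in place of hydrogen on an aromatic carbon gives a 3.9-fold lower number from compound 2 to compound 4 (0.59 log units; beyond the scatter), whereas on the other core the same change gives a 1.0-fold lower number from compound 3 to compound 1 (0.01 log units; within the scatter). The change therefore does not carry over with the same size from one core to the other: the same change on two cores in this assay, a 1.0-fold lower number (0.01 log units; within the scatter) from compound 3 to compound 1 and a 3.9-fold lower number (0.59 log units; beyond the scatter) from compound 2 to compound 4, 3.8-fold (0.58 log units) apart, beyond the scatter of two such steps. For the compounds shown here, with only one pair on each core, this shows that the step depends on the core for these four compounds, but it does not show why, nor what the step would be on any further core.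

The compounds shown leave open whether a different group in the same place, such as a hydroxyl, an ethoxy or an amine, would also give steps that differ between the two cores. Also open, as far as these compounds go, is how either core would respond if the nitro group, present in all four compounds, gave way to a carboxylic acid or an amine.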